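This account rests on a few compounds, and the source may have more. Where it says the series, first, only, none or still open, it means among the compounds named here.

Measured in a functional assay on SMMC-7721 cells (Homo sapiens) for cytotoxicity, read by MTT assay, with a stated time of 4 days; a higher number here means a weaker inhibitor, a lower number a stronger inhibitor:

- compound 1 `C=C1C[C@]23C[C@@]1(O)CC[C@H]2c1ccc(OS(=O)(=O)c2ccc(C)cc2)c(C)c1[C@@H]3Cn1cc(-c2ccc(Cl)cc2)nn1`: > 20000 nM
- compound 2 `C=C1C[C@]23C[C@@]1(O)CC[C@H]2c1ccc(OS(=O)(=O)c2ccc(C)cc2)c(C)c1[C@@H]3Cn1cc(-c2ccc(Br)cc2)nn1`: > 20000 nM
- compound 3 `C=C1C[C@]23C[C@@]1(O)CC[C@H]2c1ccc(OS(=O)(=O)c2ccc(C)cc2)c(C)c1[C@@H]3Cn1cc(-c2ccc(OC)cc2)nn1`: > 20000 nM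

Compound 3 reads as a limit in this assay, not as a number. Every value shown in the series sits at the same point, since (the limit of > 20000 nM in this assay, at which 3 of the 3 values shown sit), so compound 3 stands level with the rest and cannot be placed above or below any of them. The measured steps within the series are a step that the two limits leave unreadable from compound 1 to compound 2, a step that the two limits leave unreadable from compound 1 to compound 3 and a step that the two limits leave unreadable from compound 2 to compound 3; none of them has a readable size, so they give neither a direction nor a magnitude to carry forward.

The next compound, compound 4 `C=C1C[C@]23C[C@@]1(O)CC[C@H]2c1ccc(OS(=O)(=O)c2ccc(C)cc2)c(C)c1[C@@H]3Cn1cc(-c2ccc(C)cc2)nn1`, differs from compound 3 by methyl in place of methoxy on an aromatic carbon. The three measured steps bear on this change only in that they show exchanges at the same aromatic carbon leaving the reading at the limit each time. No step beyond the scatter is therefore expected for a step that the limit leaves unreadable from compound 3 to compound 4, and compound 4 is expected to return another limit. The estimate for compound 4 in this assay is 30000 nM, with a range from 10000 nM to 100000 nM.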

Compound 4, half-maximal inhibitory concentration: > 20000 nM
Compound 4 was reported as a limit; the forecaster's own chance of this, stated with the estimate: 85%; the middle value does not contradict the limit.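

In this assay compound 4 gives > 20000 nM, which is a limit. No step between compound 4 and compound 1, compound 2 or compound 3 can be read: the limit of > 20000 nM in this assay, at which 4 of the 4 values shown sit.

The compounds shown leave open whether any group on this aromatic carbon, or any change to the shared core, gives a readable value.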